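This account rests on a few compounds, and the source may have more. Where it says the series, first, only, none or still open, it means among the compounds named here.

Within the data shown here, compound 2 `CC(=O)Nc1ccc(Cc2noc(CCC(=O)Nc3ccccc3F)n2)cc1` is one of only two compounds measured in a functional assay on the whole organism (strain C57BL/6) for inhibition, with Mus musculus as the target, read by paw edema, with stated times of 1 h and 4 h, at a dose of 100 mg/kg by the oral route (a lower number here means less inhibition, a higher number more inhibition at the dose given (going by the name of the read-out)), where compound 2 gives 67.1% and compound 1 `CC(=O)Nc1ccc(Cc2noc(CCC(=O)O)n2)cc1` gives 75.3%; the step of a number 8.2 percentage points lower from compound 1 to compound 2 (within the scatter) leaves the two standing together. Compound 3 `CC(=O)Nc1ccc(Cc2noc(CCC(=O)Nc3ccc(F)cc3)n2)cc1` differs from compound 2 by 4-fluorophenyl in place of 2-fluorophenyl on an amide-type nitrogen. Among the measured compounds shown here, no measured step moves the fluorine around that ring; the single step known concerns a different change and stayed within the scatter. So in this assay no shift beyond the scatter is expected, the estimated step being a number 0.1 percentage points lower from compound 2 to compound 3 (within the scatter). Compound 3 is expected to give about 67%, between 52% and 80%.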

Compound 3, a percentage reported as inhibition, in the whole organism at one dose (the size of the read-out at that dose, not a potency): 64.4%
Beside the measured number, compound 3's estimate is 2.6 percentage points above it; measured number inside the range.
By their numbers in this assay, from the lowest: compounds 3, 2 and 1 (each within the scatter of the next, the first and the last beyond it).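

Moving the fluorine, with 4-fluorophenyl in place of 2-fluorophenyl on the amide-type nitrogen, gives a number 2.7 percentage points lower from compound 2 to compound 3 (within the scatter) in this assay, so this assay does not tell the two placements apart. Among these compounds, replacing hydroxy on the carbonyl carbon with (4-fluorophenyl)amino gives a number 10.9 percentage points lower from compound 1 to compound 3 (beyond the scatter), the first step here to pass the scatter, though only modestly. Nothing available explains these numbers. Still open, as far as these compounds go, is how an unsubstituted phenyl, a 4-chlorophenyl or a 4-methoxyphenyl on that nitrogen would read.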